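The compounds below may be only part of what the source reports. "The series", "measured", "known", "first", "only" and "open" are said of these compounds alone.

Measured compounds in an assay on MDA-MB-231 cells for binding affinity to C-X-C chemokine receptor type 4 (Homo sapiens), read by fluorescence and microscopy, with stated times of 10 min and 30 min; on this read-out lower numbers stand for an effect already at smaller amounts and higher numbers for an effect only at larger amounts of compound:
- compound 1 `O=C(NCc1ccc(CNS(=O)(=O)c2cccc(Cl)c2)cc1)c1ccc(F)cc1`: 1 nM
- compound 2 `O=C(NCc1ccc(CNS(=O)(=O)c2ccccc2F)cc1)c1ccc(F)cc1`: 10 nM
- compound 3 `O=C(NCc1ccc(CNS(=O)(=O)c2cccc3ccccc23)cc1)c1ccc(F)cc1`: 1000 nM

Compound 3 stands at the highest number of the three in this assay; the nearest is compound 2, with a step of a 100-fold higher number from compound 2 to compound 3 (2.00 log units; beyond the scatter), and the furthest is compound 1, with a 1000-fold higher number from compound 1 to compound 3 (3.00 log units; beyond the scatter). Both steps are well beyond the scatter, so compound 3 is the weakest of the measured set.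

The next compound, compound 4 `O=C(NCc1ccc(CNS(=O)(=O)c2ccc(F)c(F)c2)cc1)c1ccc(F)cc1`, differs from compound 3 in one place: 3,4-difluorophenyl in place of naphthalen-1-yl on a sulfonyl sulfur. This is the reverse of the two large steps just named: going from a single halogenated phenyl on the sulfonyl sulfur to naphthalen-1-yl raised the number by a 1000-fold higher number from compound 1 to compound 3 (3.00 log units; beyond the scatter) and by a 100-fold higher number from compound 2 to compound 3 (2.00 log units; beyond the scatter), so going back to a halogenated phenyl is expected to lower it by a comparable amount. Between the two single-ring compounds the halogen pattern still matters, as the step of a 10-fold higher number from compound 1 to compound 2 (1.00 log units; beyond the scatter) shows, so the landing point is uncertain within that span. For the measured compounds named here, no measured compound carries 3,4-difluorophenyl, so the exact position is an extrapolation.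

Compound 4 is therefore expected to show a large drop, a 200-fold lower number from compound 3 to compound 4 (2.30 log units; beyond the scatter), with an estimated value of 5 nM, most likely between 1 nM and 30 nM.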

Compound 4, effective concentration (reported as EC, without a stated level of effect): 10 nM
Compound 4: the middle estimate sits 2.0-fold (0.30 log units) below what was measured; the measured number falls inside the stated range.
By their numbers in this assay, from the lowest: compound 1; then compounds 2 and 4 (each within the scatter of the next); then compound 3.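

In this assay, 3,4-difluorophenyl in place of naphthalen-1-yl on the sulfonyl sulfur gives (a 100-fold lower number from compound 3 to compound 4 (2.00 log units; beyond the scatter)), so a second halogenated single ring also reads far lower than the two-ring group. Replacing 2-fluorophenyl with 3,4-difluorophenyl gives (no change at the digits printed from compound 2 to compound 4 (within the scatter)), so these two fluorinated rings cannot be told apart here, whereas replacing 3-chlorophenyl with 3,4-difluorophenyl gives (a 10-fold higher number from compound 1 to compound 4 (1.00 log units; beyond the scatter)), leaving 3-chlorophenyl alone at the lowest number of the four. Nothing available accounts for these differences.

The compounds shown leave open whether the low number of compound 1 follows the chlorine or its ring pattern, which a 3-fluorophenyl or 4-chlorophenyl group would help separate. On these data alone, how a saturated cyclohexyl ring or a piperidine amine would read on the sulfonyl sulfur also stays open.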